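The source may report more compounds than this note shows. Statements on the series, on what has been measured and on what is new or still open speak of the compounds shown alone.

Measured so far:
compound 1 `COc1cc2ncnc(Nc3ccc(Cl)cc3)c2cc1OCCCCC(=O)Nc1ccc(S(N)(=O)=O)cc1`: 7120 nM
compound 2 `COc1cc2ncnc(Nc3ccc(OC(F)(F)F)cc3)c2cc1OCCCCC(=O)Nc1ccc(S(N)(=O)=O)cc1`: 22500 nM

In a functional assay on A-431 cells (Homo sapiens) for antiproliferative activity, read by MTT assay, with a stated time of 72 h (on this read-out higher numbers stand for weaker inhibition and lower numbers for stronger inhibition), compound 1 gives 7120 nM, and compound 2 gives 22500 nM, the higher of the two numbers on record and beyond the scatter apart from compound 1. Within the data shown here, the single measured step, a 3.2-fold higher number from compound 1 to compound 2 (0.50 log units; beyond the scatter), is the only guide to what a change at this place can do. Compound 3 `COc1cc2ncnc(Nc3ccc(C(F)(F)F)cc3)c2cc1OCCCCC(=O)Nc1ccc(S(N)(=O)=O)cc1` differs from compound 2 by trifluoromethyl in place of trifluoromethoxy on an aromatic carbon. Among the measured compounds shown here, no measured pair swaps trifluoromethyl for trifluoromethoxy, so the step from compound 2 to compound 3 can only be framed loosely: the one known change at this place was modest, and compound 3 is expected to stay near compound 2, with a 1.5-fold lower number from compound 2 to compound 3 (0.18 log units; within the scatter) expected as a modest shift toward a lower number rather than a large one. Compound 3 is therefore estimated at 15000 nM, in a range from 5000 nM to 45000 nM.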

Compound 3, half-maximal inhibitory concentration: 16900 nM
Estimate against measurement, compound 3: 1.1-fold (0.05 log units) below, and the stated range covers the measured number.
By their numbers in this assay, from the lowest: compound 1; then compounds 3 and 2 (each within the scatter of the next).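

In this assay, trifluoromethyl in place of trifluoromethoxy, on an aromatic carbon para to a large group, gives a 1.3-fold lower number from compound 2 to compound 3 (0.12 log units; within the scatter) and so leaves the two fluorine-bearing groups unseparated at this place. Chloro now stands apart from both of them: trifluoromethyl in its place gives a 2.4-fold higher number from compound 1 to compound 3 (0.38 log units; beyond the scatter) and thus joins the earlier step in placing compound 1 at the low end of the three compounds. Nothing available accounts for this difference between chloro and the two fluorine-bearing groups.

Going by these compounds, all three compounds carry a halogen-bearing group at this place, so how an amine or a carboxylic acid there would read in this assay remains open. Also open, on these data alone, is whether the gap to chloro would hold with a longer chain joining the core to the amide.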